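Three Aryl-Substituted Pyrimidine Anilines and a Fourth to Come

This account rests on a few compounds, and the source may have more. Where it says the series, first, only, none or still open, it means among the compounds named here.

The study examined a small set of compounds built on one shared core. Compound 1 `Cc1cc(-c2ccccc2)cc(C)c1Nc1ccnc(Nc2ccc(C#N)cc2)n1` was measured in an ADME assay on MT4 cells (Homo sapiens) for cytotoxicity, read by MTT assay, with a stated time of 4 days (on this read-out higher numbers stand for lower toxicity in this test and lower numbers for higher toxicity in this test), where compound 1 gives 4170 nM. Compound 2 `Cc1cc(-c2cccc(F)c2)cc(C)c1Nc1ccnc(Nc2ccc(C#N)cc2)n1` gives 4120 nM in the same test, and compound 3 `Cc1cc(-c2cc(F)cc(F)c2)cc(C)c1Nc1ccnc(Nc2ccc(C#N)cc2)n1` gives 3910 nM. Compound 1 holds the highest of the three numbers, but the steps are small: a 1.0-fold lower number from compound 1 to compound 2 (0.01 log units; within the scatter) and a 1.1-fold lower number from compound 1 to compound 3 (0.03 log units; within the scatter), and between the two fluorinated analogues a 1.1-fold lower number from compound 2 to compound 3 (0.02 log units; within the scatter). All three compounds therefore sit together in this assay.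

Compound 4 `Cc1cc(C)cc(-c2cc(C)c(Nc3ccnc(Nc4ccc(C#N)cc4)n3)c(C)c2)c1` has not yet been measured. It differs from compound 1 as follows: 3,5-dimethylphenyl in place of phenyl on an aromatic carbon. The measured steps that bear on this change are those that altered the same phenyl group, and each of them stayed within the scatter. For the measured compounds named here, no step in this set has moved the number beyond the scatter, so the expectation for compound 4 is a step of about a 1.0-fold lower number from compound 1 to compound 4 (0.02 log units; within the scatter), that is, no change beyond the scatter. Compound 4 is therefore estimated at 4000 nM, within a range of 2000 nM to 8000 nM.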

Compound 4, half-maximal cytotoxic concentration: 4140 nM
Beside the measured number, compound 4's estimate is 1.0-fold (0.01 log units) below it, and the stated range covers the measured number.
By their numbers in this assay, from the lowest: compounds 3, 2, 4 and 1 (each within the scatter of the next).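

In this assay, placing 3,5-dimethylphenyl in this position gives a 1.0-fold lower number from compound 1 to compound 4 (0.00 log units; within the scatter), so a group of 8 heavy atoms in place of the 6 of phenyl leaves the number within the scatter. The earlier steps shown here had tested only fluoro on this phenyl group, and the comparisons with the fluorinated analogues now extend the picture to methyl groups, with a 1.1-fold higher number from compound 3 to compound 4 (0.02 log units; within the scatter) and a 1.0-fold higher number from compound 2 to compound 4 (0.00 log units; within the scatter), so that all four compounds sit together in this test. No evidence is given here that would account for this lack of change.

The compounds shown leave open whether a different group on this phenyl ring, such as an amine, a carboxylic acid or a longer alkyl chain, would move the number in this assay beyond the scatter. They also leave open whether a step beyond the scatter could come from changing another part of the shared core, such as the nitrile, since every step shown here alters only the one aromatic group.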